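A few compounds are considered here, and "the series" means these few. Any claim that something is new, unique, unknown or untested is made for them only; others in the source may bear on it.

Measured so far in an ADME assay on MT4 cells (Homo sapiens) for cytotoxicity, read by MTT assay, with a stated time of 96 h; on this read-out higher numbers stand for lower toxicity in this test and lower numbers for higher toxicity in this test:
Compound 1 `COc1ccc(-c2nc3cc(Cl)c(Cl)cc3[nH]2)cc1` gives 1000 nM.
Compound 2 `COc1ccc(-c2nc3cc(Cl)c(Cl)cc3[nH]2)c([N+](=O)[O-])c1` gives 2000 nM.
Compound 3 `COc1ccc(-c2nc3cc([N+](=O)[O-])ccc3[nH]2)c(OC)c1` gives > 100000 nM.

For compound 3 this is a limit of the assay, not a number. For the measured compounds named here, compound 2 stands together with compound 1: the only measured step is a 2.0-fold higher number from compound 1 to compound 2 (0.30 log units; within the scatter), within the scatter, so the two cannot be told apart. Compound 4 `COc1ccc(-c2nc3cc(Cl)c(Cl)cc3[nH]2)c(N)c1` differs from compound 2 by amino in place of nitro on an aromatic carbon. Going by the values given here, no measured step trades nitro for amino, and the one step known, a 2.0-fold higher number from compound 1 to compound 2 (0.30 log units; within the scatter), changed little, so no firm direction can be drawn. Compound 4 is therefore expected to stay close to compound 2, with a 1.5-fold higher number from compound 2 to compound 4 (0.18 log units; within the scatter) as the expected step. The estimate for compound 4 in this assay is 3000 nM, between 700 nM and 15000 nM.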

Compound 4, half-maximal cytotoxic concentration: 3000 nM
For compound 4 middle estimate and measured number coincide at the digits printed, and the stated range covers the measured number.
By their numbers in this assay, from the lowest: compounds 1, 2 and 4 (each within the scatter of the next, the first and the last beyond it). At a limit, above all of these: compound 3.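

At this place on the ring, ortho to a large group, amino and nitro cannot be told apart in this assay (a 1.5-fold higher number from compound 2 to compound 4 (0.18 log units; within the scatter)). Set against hydrogen, however, amino gives the first measured step beyond the scatter, although only a modest one (a 3.0-fold higher number from compound 1 to compound 4 (0.48 log units; beyond the scatter)). Nothing measured here explains either step.

As far as these compounds go, whether a hydroxyl group or an acetamide in the same place would stay with these compounds remains open. So does whether a larger amine, such as dimethylamino, would give a step beyond the scatter from compound 4.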